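The source may report more compounds than this note shows. Statements on the series, on what has been measured and on what is new or still open speak of the compounds shown alone.

Measured compounds:
compound 1 `CC1(C)CN(c2cc(COc3ccc(F)c(F)c3F)nc(-c3ccccn3)n2)C1`: 25.1 nM
compound 2 `COC1(COc2cc(COc3ccc(F)c(F)c3F)nc(-c3ccccn3)n2)COC1`: 501 nM

In a functional assay on cells for antagonist activity at Free fatty acid receptor 1 (Homo sapiens), read by TR-FRET and inositol phosphate accumulation, with a stated time of 2 h (a higher number here means a weaker inhibitor, a lower number a stronger inhibitor), compound 2 gives the higher of the two numbers, standing a 20-fold higher number from compound 1 to compound 2 (1.30 log units; beyond the scatter) from compound 1, a step that exchanged the whole group at that ring position. Compound 3 `Fc1ccc(OCc2cc(OCC3(F)COC3)nc(-c3ccccn3)n2)c(F)c1F` differs from compound 2 by fluoro in place of methoxy on a saturated ring carbon. Going by the values given here, no measured step touches this part of the structure, so the only guide is that compound 2 itself is the weaker of the pair. Compound 3 is therefore expected to stay close to compound 2, with a step of a 1.3-fold lower number from compound 2 to compound 3 (0.10 log units; within the scatter). The estimate for compound 3 is 400 nM, within 150 nM to 1200 nM.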

Compound 3, half-maximal inhibitory concentration in the Free fatty acid receptor 1 assay: 63.1 nM
Compound 3: the middle estimate sits 6.3-fold (0.80 log units) above what was measured; measured number below the stated range.
By their numbers in the Free fatty acid receptor 1 assay, from the lowest: compound 1; then compound 3; then compound 2.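

In the Free fatty acid receptor 1 assay, the substituent on the saturated ring carbon proves to matter on its own: a 7.9-fold lower number from compound 2 to compound 3 (0.90 log units; beyond the scatter). Much of the loss seen with the (3-methoxyoxetan-3-yl)methoxy group is thus recovered without changing the rest of the side chain, yet a gap to the 3,3-dimethylazetidin-1-yl group remains: a 2.5-fold higher number from compound 1 to compound 3 (0.40 log units; beyond the scatter). In a physicochemical assay for lipophilicity, at pH 7.4 (on this read-out higher numbers stand for higher lipophilicity and lower numbers for lower lipophilicity), compound 2 reads 3.5 and compound 3 reads 4 on this scale. The same exchange of methoxy for fluoro also shifts the measured lipophilicity: the measured distribution coefficient of compound 2, 3.5, and of compound 3, 4, a number 0.50 log units higher (beyond the scatter)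

A single pair cannot tell whether the stronger inhibition follows that shift or the fluoro itself. From the compounds shown here alone, how a hydroxy or methyl group on that ring carbon would read stays open.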